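A few compounds are considered here, and "the series" means these few. Any claim that something is new, unique, unknown or untested is made for them only; others in the source may bear on it.

Measured compounds:
- compound 1, `Nc1ccccc1NC(=O)c1ccc(CSC(=S)N2CCN(C3CCCCC3)CC2)cc1`, gives 76.1% in a functional assay on HeLa cells (Homo sapiens) for antiproliferative activity, read by CCK-8 assay, with a stated time of 72 h, tested at 8 uM; on this read-out lower numbers stand for a weaker effect and higher numbers for a stronger effect at the one concentration tested
- compound 2, `CC1CCCCN1C(=S)SCc1ccc(C(=O)Nc2ccccc2N)cc1`, gives 76.3% in this assay

Compound 2 and compound 1 share the same core and differ only in the ring attached to the thiocarbonyl carbon. Their two numbers in this assay lie within the usual scatter of each other, so neither can be placed above the other; compound 2 is simply one of two closely matched values.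

Compound 3, `Nc1ccccc1NC(=O)c1ccc(CSC(=S)N2CCCc3ccccc32)cc1`, has not yet been measured in this assay. It differs from compound 2 in one place: 1,2,3,4-tetrahydroquinolin-1-yl in place of 2-methylpiperidin-1-yl on a thiocarbonyl carbon. Going by the values given here, no measured pair shows what such a change does here. Given that the two measured rings on the thiocarbonyl carbon gave matching numbers, no step beyond the scatter is expected from compound 2 to compound 3, and the estimated step is a number 2.3 percentage points lower from compound 2 to compound 3 (within the scatter). Compound 3 is therefore expected to give about 74% in this assay, with a likely range from 55% to 88%.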

Compound 3, a percentage reported as inhibition, at one concentration (the size of the read-out at that concentration, not a potency): 35.7%
Compound 3: middle estimate off by 38.3 percentage points, on the high side; the measured number lies below the stated range.
By their numbers in this assay, from the lowest: compound 3; then compounds 1 and 2 (each within the scatter of the next).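

In this assay the exchange of 2-methylpiperidin-1-yl for 1,2,3,4-tetrahydroquinolin-1-yl on a thiocarbonyl carbon gives a number 40.6 percentage points lower from compound 2 to compound 3 (beyond the scatter) in this series. Compounds 1 and 2 alone, with numbers within the scatter of each other, gave no sign that this position could respond so strongly; it clearly does not accept every ring equally. The entering group adds a six-membered aromatic ring of carbon only, but nothing shown explains why the read-out falls with this change.

The compounds shown leave open whether the aromatic ring itself goes with the drop, which an open-chain N-methylanilino group or a plain piperidin-1-yl group could help to separate. They also leave open whether the same step would appear at other concentrations or in other cell lines.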